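Exchanging Methyl for Chloro in an Oral Exposure Series

This account rests on a few compounds, and the source may have more. Where it says the series, first, only, none or still open, it means among the compounds named here.

Measured compounds:
- compound 1 `Cc1ccc(-c2nc(=O)o[nH]2)c(-c2ccc([C@@H](C)N(CC3CC3)c3nc4c(C(=O)O)cccc4o3)cc2)c1`: 2920 nM
- compound 2 `CCCCN(c1nc2c(C(=O)NS(C)(=O)=O)cccc2o1)[C@H](C)c1ccc(-c2ccccc2-c2nnn[nH]2)cc1`: 40.4 nM
- compound 3 `CCCCN(c1nc2c(-c3ccccn3)cccc2o1)[C@H](C)c1ccc(-c2ccccc2-c2nnn[nH]2)cc1`: 124 nM

In an ADME assay on the whole organism (Macaca fascicularis) for pharmacokinetics, read by LC-MS, using cassette dosing, at a dose of 1 mg/kg by the oral route (a higher number here means more compound in the circulation at the dose given, a lower number less compound in the circulation), compound 1 stands highest of the three, well beyond the scatter above both compound 2 and compound 3. Within the data shown here, the only measured step is a 3.1-fold higher number from compound 2 to compound 3 (0.49 log units; beyond the scatter); it changes a different part of the molecule and does not bear on the change considered here. Compound 4 `C[C@H](c1ccc(-c2cc(Cl)ccc2-c2nc(=O)o[nH]2)cc1)N(CC1CC1)c1nc2c(C(=O)O)cccc2o1` differs from compound 1 as follows: chloro in place of methyl on an aromatic carbon. Among the measured compounds shown here, no measured pair shows what this swap does in this assay, so the expectation is a step no larger than the scatter, in either direction. Compound 4 is therefore estimated at 2600 nM (range 900 nM to 7500 nM), an expected step of a 1.1-fold lower number from compound 1 to compound 4 (0.05 log units; within the scatter).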

Compound 4, maximal plasma concentration: 976 nM
Estimate against measurement, compound 4: 2.7-fold (0.43 log units) above; the range from low to high includes it.
By their numbers in this assay, from the lowest: compound 2; then compound 3; then compound 4; then compound 1.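

Exchanging methyl for chloro on this aromatic carbon, para to a group of 6 heavy atoms, is not a neutral swap in this assay: it gives a 3.0-fold lower number from compound 1 to compound 4 (0.48 log units; beyond the scatter). Among the compounds shown, this is the only pair that tests this position, and it shows that changing one heavy atom here can move the plasma level beyond the usual scatter. Nothing measured here gives a reason for this step.

Going by these compounds, whether fluoro, methoxy or plain hydrogen at this position would keep the level of compound 1 remains open. So does whether chloro would give a similar step with a butyl chain in place of the cyclopropylmethyl group.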